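The source may report more compounds than this note shows. Statements on the series, on what has been measured and on what is new or still open speak of the compounds shown alone.

Going by the values given here, in a functional assay on K562 cells (Homo sapiens) for antiproliferative activity, read by CCK-8 assay, with a stated time of 72 h (on this read-out lower numbers stand for stronger inhibition of growth and higher numbers for weaker inhibition of growth), three compounds have numbers so far. Compound 1 (`CCC1C(=O)N(C)c2cnc(-n3ccc4cc(C(=O)NC(C)C)ccc43)nc2N1c1ccn(C)n1`) gives 8910 nM and stands highest of the three, which makes it the weakest growth inhibitor among them. Compound 2 (`CCCNS(=O)(=O)c1ccc(Nc2ncc3c(n2)N(C2CCCC2)[C@H](CC)C(=O)N3C)cc1`) gives 548 nM and compound 3 (`CC[C@@H]1C(=O)N(C)c2cnc(-n3ccc4cc(C(=O)NC5CCCC5)ccc43)nc2N1C1CCCC1`) gives 414 nM and these two numbers lie within the usual scatter of each other, while both sit lower than compound 1 by well beyond that scatter.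

Compound 4 (`CCC1C(=O)N(C)c2cnc(-n3ccc4cc(C(=O)NC5CCCC5)ccc43)nc2N1c1ccn(C)n1`) is compound 1 with a single change (cyclopentyl in place of isopropyl on an amide-type nitrogen) in which cyclopentyl takes the place of isopropyl on an amide-type nitrogen. Among the compounds with values here, no pair of measured compounds shows this change alone. Compound 3 also carries cyclopentyl on an amide-type nitrogen and gives 414 nM but it differs from compound 1 elsewhere too, so its number hints at a direction and not at a size. A moderate drop is therefore expected (the estimated step runs a 3.0-fold lower number from compound 1 to compound 4 (0.47 log units; beyond the scatter)) and it should lie somewhat beyond the scatter, although a step inside the scatter would be no surprise. Compound 4 is estimated at 3000 nM (expected range 900 nM to 9000 nM).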

Compound 4, concentration for 50% growth inhibition: 31300 nM
Estimate against measurement, compound 4: 10-fold (1.02 log units) below; the whole stated range lies below it.
By their numbers in this assay, from the lowest: compounds 3 and 2 (each within the scatter of the next); then compound 1; then compound 4.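

Going by these compounds alone, this pair gives the first direct reading of this change at this position: in this assay, cyclopentyl in place of isopropyl on an amide-type nitrogen gives a 3.5-fold higher number from compound 1 to compound 4 (0.55 log units; beyond the scatter) and so weaker inhibition of growth. With everything else in compound 1 held the same, the step shows that this nitrogen's substituent can shift the read-out by more than ordinary repeat-to-repeat variation, and that the added ring and its extra carbon atoms do not help on this core. No independent measurement accompanies the result, so the reason for the step remains unknown.

A single pair gives one direction on one version of the core, so it cannot show whether the same swap would raise the number when the other substituents differ, as they do in compound 3. It also leaves open how other groups on this amide-type nitrogen would behave, such as a longer chain, a chain ending in an amine or a carboxylic acid, or a plain methyl group.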